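The source may hold more compounds than are shown below. What is called first, only, known or untested is meant among the compounds shown, and "the series" means these compounds.

Compound 1 `Cc1nc(-c2ccccc2)c(C(=O)N2CCN(c3cccc(Cl)c3)CC2)o1`: 39.2 nM
Compound 2 `COc1ccc(-c2nc(C)oc2C(=O)N2CCN(c3cccc(Cl)c3)CC2)cc1OC`: "not active" (no number reported)
Compound 3 `COc1ccc(-c2nc(C)oc2C(=O)N2CCN(c3cccc(Cl)c3)CC2)cc1`: "not active" (no number reported)

All three share one core and were tested in a functional assay on HL-60 cells (Homo sapiens) for inhibition, read by MTT assay, with a stated time of 72 h; on this read-out higher numbers stand for weaker inhibition and lower numbers for stronger inhibition. Within the data shown here, compound 1 gives 39.2 nM, the only number in the set. Among the measured compounds shown here, compound 2 was reported as "not active" (no number reported), and compound 3 as "not active" (no number reported), each without a number, so no step between measured compounds can be sized here.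

Compound 4 `Cc1nc(-c2ccccc2)c(C(=O)N2CCN(c3cccc(C(F)(F)F)c3)CC2)o1` differs from compound 1 in one place: trifluoromethyl in place of chloro on an aromatic carbon. For the measured compounds named here, no measured pair shows this same change, so the expectation rests on compound 1 alone. The step of a 1.3-fold higher number from compound 1 to compound 4 (0.11 log units; within the scatter) is expected to stay within the usual scatter, in no clear direction. Compound 4 is therefore estimated at 50 nM, with a range from 15 nM to 160 nM.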

Compound 4, half-maximal inhibitory concentration: 153 nM
The estimate for compound 4 lay 3.1-fold (0.49 log units) below the measured number, and the stated range covers the measured number.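

In this assay, trifluoromethyl in place of chloro gives a 3.9-fold higher number from compound 1 to compound 4 (0.59 log units; beyond the scatter) and so shows that this spot on the chlorine-bearing ring responds to the group it carries. The loss is modest, and compound 4 still gives a number, so this position tolerates the change to a degree. Nothing in the data at hand gives a reason for the shift.

As far as these compounds go, it remains open how a nitrile, an amine or a carboxylic acid would fare at this position. One replacement also cannot show whether the trend would hold for other groups.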